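This account rests on a few compounds, and the source may have more. Where it says the series, first, only, none or still open, it means among the compounds named here.

Compound 2 `O=S(=O)(NCCCNCc1ccc(Cl)c(C(F)(F)F)c1)c1cc(C(F)(F)F)cc(C(F)(F)F)c1` gives 8600 nM in a functional assay on BE(2)-C cells (Homo sapiens) for inhibition, read by MTT assay, with a stated time of 72 h (on this read-out lower numbers stand for stronger inhibition of growth and higher numbers for weaker inhibition of growth), and stands as the lower of the two numbers in hand, within the scatter of compound 1 `O=S(=O)(NCCCNCc1ccccc1Cl)c1cc(C(F)(F)F)cc(C(F)(F)F)c1`, which in this assay gives 15000 nM. Going by the values given here, the only measured step, a 1.7-fold lower number from compound 1 to compound 2 (0.24 log units; within the scatter), swapped the group on the saturated chain carbon bound to an amine nitrogen without leaving the scatter. Compound 3 `O=S(=O)(NCCCNCC1COc2ccccc2O1)c1cc(C(F)(F)F)cc(C(F)(F)F)c1` alters the same place: 2,3-dihydro-1,4-benzodioxin-2-yl in place of 4-chloro-3-(trifluoromethyl)phenyl on a saturated chain carbon bound to an amine nitrogen. Among the compounds with values here, no measured step covers the entering group, and the one step at this place stayed within the scatter, so no step beyond the scatter is expected. Compound 3 is estimated at 10000 nM in this assay, range 4000 nM to 30000 nM, an expected step of a 1.2-fold higher number from compound 2 to compound 3 (0.07 log units; within the scatter).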

Compound 3, concentration for 50% growth inhibition: 2800 nM
The estimate for compound 3 lay 3.6-fold (0.55 log units) above the measured number, outside the stated range (below it).
By their numbers in this assay, from the lowest: compound 3; then compounds 2 and 1 (each within the scatter of the next).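

Going by these compounds alone, at the saturated chain carbon bound to an amine nitrogen, 2,3-dihydro-1,4-benzodioxin-2-yl gives the first steps beyond the scatter in this assay: a 3.1-fold lower number from compound 2 to compound 3 (0.49 log units; beyond the scatter) and a 5.4-fold lower number from compound 1 to compound 3 (0.73 log units; beyond the scatter). This position therefore responds to the group it carries, and the substituted phenyl groups of compound 1 and compound 2 do not set the lowest number in hand. No measurement here accounts for this change.

As far as these compounds go, it remains open whether the two oxygen atoms of the entering group matter. A tetrahydropyranyl or cyclohexyl group at this place would help separate the contribution of each ring.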